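The source may hold more compounds than are shown below. What is called first, only, known or untested is meant among the compounds shown, and "the series" means these compounds.

For the measured compounds named here, in a functional assay on HL-60 cells (Homo sapiens) for cytotoxicity, read by WST assay, with a stated time of 48 h (on this read-out lower numbers stand for stronger inhibition and higher numbers for weaker inhibition), compound 1 `COC[C@H](C(C)C)C(c1ccc(O)c(OC)c1)c1ccc(O)c(OC)c1` gives 72000 nM and compound 2 `COc1cc(C(c2ccc(O)c(OC)c2)[C@H](CF)C(C)C)ccc1O` gives 19000 nM, so compound 2 holds the lower of the two numbers so far. Going by the values given here, the only measured step, a 3.8-fold lower number from compound 1 to compound 2 (0.58 log units; beyond the scatter), puts fluoro in place of methoxy and is modest. Next in the series is compound 3 `CCCCCCCC[C@H](C(C)C)C(c1ccc(O)c(OC)c1)c1ccc(O)c(OC)c1`, with the change heptyl in place of fluoro on a saturated chain carbon, three bonds along the chain from two aromatic carbons. Among the compounds with values here, no measured compound carries a chain of this length, so that single step bears on the change only indirectly. It shows that the number in this assay can move with a change at this place, but it does not fix a direction for heptyl. A step of similar modest size is therefore expected, leaning towards a lower number, with a real chance of none beyond the scatter. The estimated change is a 2.1-fold lower number from compound 2 to compound 3 (0.32 log units; beyond the scatter). Compound 3 is estimated at 9000 nM, with an expected range of 2500 nM to 30000 nM.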

Compound 3, half-maximal inhibitory concentration: 3700 nM
Beside the measured number, compound 3's estimate is 2.4-fold (0.39 log units) above it; the range from low to high includes it.
By their numbers in this assay, from the lowest: compound 3; then compound 2; then compound 1.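

In this assay, for the compounds shown here, the step of a 5.1-fold lower number from compound 2 to compound 3 (0.71 log units; beyond the scatter) gives the direction that the single earlier step could not fix for heptyl: this saturated chain carbon, three bonds along the chain from two aromatic carbons, takes a much larger hydrocarbon group, and the number falls rather than rises. The step of a 19-fold lower number from compound 1 to compound 3 (1.29 log units; beyond the scatter) is the only large one in the series and puts compound 3 lowest of the three, with its steps to both other compounds beyond the scatter, so the order at this place runs heptyl, then fluoro, then methoxy. Nothing shown gives a reason for this order or says what heptyl contributes at this place.

With heptyl as the only chain among these compounds, the three numbers cannot show whether the value follows chain length, and a shorter chain such as butyl or a longer chain such as decyl would be needed to test that. Going by these compounds, it also remains open whether a chain carrying an amine or a carboxylic acid keeps the lower number seen with heptyl, or whether the order of the three groups holds on any other read-out.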